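The source may report more compounds than this note shows. Statements on the series, on what has been measured and on what is new or still open speak of the compounds shown alone.

In a functional assay on MGC-803 cells (Homo sapiens) for antiproliferative activity, read by CellTiter-Glo, with a stated time of 72 h (on this read-out higher numbers stand for weaker inhibition and lower numbers for stronger inhibition), compound 1 (`Cc1ccc(-c2cc(/C=C/c3ccc(C(=O)NO)cc3)ccn2)c(F)c1`) gives 770 nM while compound 3 (`Cc1ccc(-c2cncc(/C=C/c3ccc(C(=O)NO)cc3)c2)c(F)c1`) gives 2240 nM on the same read-out. Compound 2 (`O=C(NO)c1ccc(/C=C/c2cc(-c3ccc(C(F)(F)F)cc3)ncc2F)cc1`) returns only a limit of > 10000 nM in this assay and no number. Of the two true numbers, compound 3 holds the higher, which means weaker inhibition, and its gap to compound 1 lies beyond the scatter.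

The next compound to be tested is compound 4 (`COc1ccc(F)cc1-c1cncc(/C=C/c2ccc(C(=O)NO)cc2)c1`). It differs from compound 3 in one place, with 5-fluoro-2-methoxyphenyl in place of 2-fluoro-4-methylphenyl on an aromatic carbon, two atoms from the ring nitrogen and meta to a large group (5-fluoro-2-methoxyphenyl in place of 2-fluoro-4-methylphenyl on an aromatic carbon). Among the compounds with values here, no measured pair differing in one place shows what such a swap does. Starting from compound 3 at 2240 nM as the reference, no step beyond the scatter is expected in this assay in either direction. The estimated change is a 1.1-fold lower number from compound 3 to compound 4 (0.05 log units; within the scatter) under this expectation. Compound 4 is expected at an estimated 2000 nM with a range of 700 nM to 6000 nM once it is measured.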

Compound 4, half-maximal inhibitory concentration: 3360 nM
The estimate for compound 4 lay 1.7-fold (0.23 log units) below the measured number; the measured number falls inside the stated range.
By their numbers in this assay, from the lowest: compound 1; then compounds 3 and 4 (each within the scatter of the next). At a limit, above all of these: compound 2.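

In this assay, within the data shown here, 5-fluoro-2-methoxyphenyl in place of 2-fluoro-4-methylphenyl gives a 1.5-fold higher number from compound 3 to compound 4 (0.18 log units; within the scatter), the first measured one-place change on this aromatic carbon, two atoms from the ring nitrogen. This exchange of one substituted phenyl for another, with 1 hydrogen-bond acceptor in the entering group and 0 in the leaving group, therefore leaves the number within the scatter. Nothing measured here accounts for the size of this step.

Going by these compounds, it remains open whether a group of another kind on this carbon, such as an amine, a carboxylic acid or an unsubstituted phenyl, would move the number beyond the scatter. On these data alone, it is equally open whether the same exchange would behave alike on the core of compound 1.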